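Replacing the dichlorophenyl group of compound 1

The compounds below may be only part of what the source reports. "The series", "measured", "known", "first", "only" and "open" are said of these compounds alone.

Compound 1 `CN(C)CCn1cnnc1-c1cc(Oc2ccc(NC(=O)N/N=C/c3c(Cl)cccc3Cl)cc2F)ccn1` gives 350 nM in a functional assay on NCI-H460 cells (Homo sapiens) for cytotoxicity, read by MTT assay, with a stated time of 72 h; a higher number here means a weaker inhibitor, a lower number a stronger inhibitor.
Compound 2 `CN(C)CCn1cnnc1-c1cc(Oc2ccc(NC(=O)N/N=C/c3c(O)ccc4ccccc34)cc2F)ccn1` gives 890 nM in this assay.
Compound 3 `COc1ccc(/C=N/NC(=O)Nc2ccc(Oc3ccnc(-c4nncn4CCN(C)C)c3)c(F)c2)cc1O` gives 620 nM in this assay.

Among these three, compound 1 has the lowest number; its nearest neighbour is compound 3, at a step of a 1.8-fold higher number from compound 1 to compound 3 (0.25 log units; within the scatter), and its furthest is compound 2, at a 2.5-fold higher number from compound 1 to compound 2 (0.41 log units; beyond the scatter). The unmeasured compound 4 `COc1cc(/C=N/NC(=O)Nc2ccc(Oc3ccnc(-c4nncn4CCN(C)C)c3)c(F)c2)ccc1O` differs from compound 1 in one place: 4-hydroxy-3-methoxyphenyl in place of 2,6-dichlorophenyl on a carbon with a double bond to nitrogen.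

Going by the values given here, two measured steps bear on this change, since both also exchange the 2,6-dichlorophenyl group on the same carbon. The step of a 2.5-fold higher number from compound 1 to compound 2 (0.41 log units; beyond the scatter) is modest and beyond the scatter, while a 1.8-fold higher number from compound 1 to compound 3 (0.25 log units; within the scatter) stays within it. Compound 3 carries the 3-hydroxy-4-methoxyphenyl group, the closest counterpart to the 4-hydroxy-3-methoxyphenyl group entering compound 4, and between compound 2 and compound 3 the step of a 1.4-fold lower number from compound 2 to compound 3 (0.16 log units; within the scatter) is small. Compound 4 is therefore expected to behave much like compound 3, with a step of a 1.7-fold higher number from compound 1 to compound 4 (0.23 log units; within the scatter) that may not exceed the scatter. The estimate for compound 4 in this assay is 600 nM, within 300 nM to 1200 nM.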

Compound 4, half-maximal inhibitory concentration: 57 nM
Beside the measured number, compound 4's estimate is 11-fold (1.02 log units) above it; the whole stated range lies above it.
By their numbers in this assay, from the lowest: compound 4; then compounds 1, 3 and 2 (each within the scatter of the next, the first and the last beyond it).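

In this assay, the placing of the hydroxy and methoxy groups on the ring matters far more than the opening compounds suggested: exchanging the 3-hydroxy-4-methoxyphenyl group for the 4-hydroxy-3-methoxyphenyl group gives an 11-fold lower number from compound 3 to compound 4 (1.04 log units; beyond the scatter) even though the two groups differ only in that arrangement. Compound 4 also stands clear of the other two, with a 6.1-fold lower number from compound 1 to compound 4 (0.79 log units; beyond the scatter) and a 16-fold lower number from compound 2 to compound 4 (1.19 log units; beyond the scatter), so this carbon can shift the number well beyond the earlier 2.5-fold higher number from compound 1 to compound 2 (0.41 log units; beyond the scatter) among the compounds shown. Nothing measured here explains why these two arrangements differ.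

As far as these compounds go, it remains open whether the gain needs both groups, or whether a phenyl carrying only a hydroxy or only a methoxy group would keep it. An amine in place of the hydroxy of the 4-hydroxy-3-methoxyphenyl group is also untested among the compounds shown.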